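The source may hold more compounds than are shown below. What is called first, only, known or untested is meant among the compounds shown, and "the series" means these compounds.

Values from a functional assay on MCF7 cells (Homo sapiens), read by MTT assay, with a stated time of 48 h (on this read-out higher numbers stand for weaker inhibition and lower numbers for stronger inhibition), follow.
- compound 1 `CCn1c(C(=O)NCCCN(C)C)ccc1C(CC)(CC)c1ccc(OCC(=O)C(C)(C)C)c(C)c1` gives 340 nM
- compound 2 `CCOC(=O)CN(C)C(=O)c1ccc(C(CC)(CC)c2ccc(OCC(O)C(C)(C)C)c(C)c2)n1CC` gives 9200 nM

Compound 2 at 9200 nM holds the higher of the two numbers, beyond the scatter from compound 1. Compound 3 `CCn1c(C(=O)NCCN(C)C)ccc1C(CC)(CC)c1ccc(OCC(O)C(C)(C)C)c(C)c1` differs from compound 2 by (2-(dimethylamino)ethyl)amino in place of ((ethoxycarbonyl)methyl)(methyl)amino on a carbonyl carbon with (2-(dimethylamino)ethyl)amino in place of ((ethoxycarbonyl)methyl)(methyl)amino on a carbonyl carbon. Among the compounds with values here, no step between measured compounds covers this change. Within the data shown here, the only guide is compound 1 at 340 nM showing that lower numbers occur. The expected step of a 6.1-fold lower number from compound 2 to compound 3 (0.79 log units; beyond the scatter) is downward and beyond the scatter in this assay. For compound 3 the estimated value is 1500 nM with an expected range of 300 nM to 7000 nM.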

Compound 3, half-maximal inhibitory concentration: 660 nM
For compound 3 the middle estimate is 2.3-fold (0.36 log units) above the measured one, within the range that was stated.
By their numbers in this assay, from the lowest: compounds 1 and 3 (each within the scatter of the next); then compound 2.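

In this assay, the group on a carbonyl carbon whose other neighbour is an aromatic carbon strongly affects the read-out: (2-(dimethylamino)ethyl)amino in place of ((ethoxycarbonyl)methyl)(methyl)amino gives a 14-fold lower number from compound 2 to compound 3 (1.14 log units; beyond the scatter). Within the data shown here, this is the only step that changes one place alone, so it is the only direct sign that this position matters. Nothing at hand explains the size of the step.

Open, as far as these compounds go, is whether the step follows the dimethylamino end or the amide hydrogen, since both enter together. Also open, from the compounds shown here alone, is how a carboxylic acid or a terminal morpholine would read at this position.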